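The source may report more compounds than this note shows. Statements on the series, on what has been measured and on what is new or still open speak of the compounds shown alone.

Of the compounds shown here, two with a shared core have been tested in an ADME assay on MT4 cells (Homo sapiens) for cytotoxicity, read by MTT assay, with a stated time of 4 days; on this read-out lower numbers stand for higher toxicity in this test and higher numbers for lower toxicity in this test. Compound 1, `Cc1cc(-c2ccc(Cl)cc2)cc(C)c1Nc1ccnc(Nc2ccc(C#N)cc2)n1`, gives 4190 nM in this assay, the highest of the two numbers. Going by the values given here, compound 2, `Cc1cc(-c2ccccc2F)cc(C)c1Nc1ccnc(Nc2ccc(C#N)cc2)n1`, gives 2120 nM in this assay, and the only step between measured compounds, a 2.0-fold lower number from compound 1 to compound 2 (0.30 log units; within the scatter), stays within the scatter. The third compound, compound 3, `Cc1ccc(-c2cc(C)c(Nc3ccnc(Nc4ccc(C#N)cc4)n3)c(C)c2)cc1`, has not yet been measured. It differs from compound 1 in one place: methyl in place of chloro on an aromatic carbon. Among the compounds with values here, no measured step swaps chloro for methyl, so the only guide is that the one step so far, from a 4-chlorophenyl to a 2-fluorophenyl, stayed within the scatter. On that basis no step beyond the scatter is expected for compound 3 in this assay, so the expected step is a 1.0-fold lower number from compound 1 to compound 3 (0.02 log units; within the scatter). The estimate for compound 3 in this assay is 4000 nM, within a range from 1500 nM to 10000 nM.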

Compound 3, half-maximal cytotoxic concentration: 5570 nM
Estimate against measurement, compound 3: 1.4-fold (0.14 log units) below, within the range that was stated.
By their numbers in this assay, from the lowest: compounds 2, 1 and 3 (each within the scatter of the next, the first and the last beyond it).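

In this assay the step from chloro to methyl, at the place para to a large group, is a 1.3-fold higher number from compound 1 to compound 3 (0.12 log units; within the scatter) and so shows that these two small groups cannot be told apart here. Going by these compounds alone, the change from 2-fluorophenyl to 4-methylphenyl gives a 2.6-fold higher number from compound 2 to compound 3 (0.42 log units; beyond the scatter) and is the first step in this set beyond the scatter, although a modest one, and it alters both the group and where that group sits on the phenyl ring. No measurement shown here offers a reason for either step.

As far as these compounds go, whether the modest step follows the group or its place stays open, since 4-fluorophenyl and 2-methylphenyl would be needed to separate the two. From the compounds shown here alone, how an amine, a carboxylic acid or a longer chain at this place would read is also open.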